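The source may report more compounds than this note shows. Statements on the series, on what has been measured and on what is new or still open speak of the compounds shown alone.

Three compounds share one core and differ only in the group attached through the ether oxygen: compound 1 `Cc1ccc(Oc2ccc3nc(COc4cccc(C(=O)O)c4)n(C)c3n2)cc1F`, compound 2 `Cn1c(COc2cccc(C(=O)O)c2)nc2cnc(Oc3ccc4c(c3)OCC4)cc21` and compound 3 `Cn1c(COc2cccc(C(=O)O)c2)nc2ccc(Oc3ccccn3)cc21`. In a physicochemical assay for lipophilicity, read by LC-MS, in phosphate buffer, measured as octanol-water partition, with a stated time of 30 min, at pH 7.4, tested at 200 mM (on this read-out lower numbers stand for lower lipophilicity and higher numbers for higher lipophilicity), compound 1 gives 2.1, compound 2 gives 0.6 and compound 3 gives 0.4. Compound 3 carries the smallest of the three numbers, although its gap to compound 2 lies within the scatter, whereas compound 1 sits beyond the scatter above it. Compound 4 `Cc1ccnc(Oc2ccc3nc(COc4cccc(C(=O)O)c4)n(C)c3c2)c1` differs from compound 3 in one place: methyl in place of hydrogen on an aromatic carbon. Among the compounds with values here, no pair of measured compounds shows this same change. A small rise, just beyond the scatter, is expected, a number 0.40 log units higher from compound 3 to compound 4 (beyond the scatter). Compound 4 is therefore estimated at 0.8, within a range from 0.4 to 1.2.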

Compound 4, distribution coefficient: 0.8
The estimate for compound 4 equals the measured number at the digits printed; low and high end bracket the measured number.
By their numbers in this assay, from the lowest: compounds 3, 2 and 4 (each within the scatter of the next, the first and the last beyond it); then compound 1.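

In this assay, within the data shown here, going from pyridin-2-yl to 4-methylpyridin-2-yl gives a number 0.40 log units higher from compound 3 to compound 4 (beyond the scatter) and is the first change in a single place that can be read here. It shows that one added methyl, on the carbon opposite the ring nitrogen, is enough to shift this number modestly. Nothing measured here explains the size of this step. From the compounds shown here alone, whether an ethyl, a methoxy or an amine at this carbon would shift the number further stays open. So does whether methyl on another carbon of this ring would give a similar step.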